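This account rests on a few compounds, and the source may have more. Where it says the series, first, only, none or still open, it means among the compounds named here.

Measured compounds:
Compound 1, `CN(C)c1ccc(/C=C2\CCC/C(=C\c3ccccc3[N+](=O)[O-])C2=O)cc1`, gives 4.86 in a physicochemical assay for lipophilicity; on this read-out lower numbers stand for lower lipophilicity and higher numbers for higher lipophilicity.
Compound 2, `O=C1/C(=C/c2ccc(F)cc2)CCC/C1=C\c1cccc([N+](=O)[O-])c1`, gives 5.06 in this assay.
Compound 3, `O=C1/C(=C/c2ccccc2)CCC/C1=C\c1ccc([N+](=O)[O-])cc1`, gives 5.08 in this assay.

All three share a core built around a cyclic ketone carrying two benzylidene arms, one of which bears a nitro group. Compound 1 has the lowest of the three numbers in this assay, but its gap to compound 2 and its gap to compound 3 both lie within the usual scatter of repeated measurements, so the three compounds cannot be told apart on this read-out.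

The next compound, compound 4, `O=C1/C(=C/c2ccccc2)CCC/C1=C\c1ccccc1[N+](=O)[O-]`, has not yet been measured in this assay. It differs from compound 1 in one place: hydrogen in place of dimethylamino on an aromatic carbon. For the measured compounds named here, no pair of measured compounds differing in a single place is available to show how large such a step tends to be, so the expectation rests on the spread of the three values. Compound 3, which also carries a plain phenyl on one arm, gives 5.08. Compound 4 is therefore expected to land close to that value, a small step upward from compound 1 that would not exceed the scatter: a number 0.14 log units higher from compound 1 to compound 4 (within the scatter). The estimate for compound 4 in this assay is 5, with a likely range from 4.7 to 5.3.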

Compound 4, partition coefficient: 4.86
The estimate for compound 4 lay 0.14 log units above the measured number; low and high end bracket the measured number.
By their numbers in this assay, from the lowest: compounds 1, 4, 2 and 3 (each within the scatter of the next).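

In this assay, for the compounds shown here, the swap of 4-(dimethylamino)phenyl for phenyl gives no change at the digits printed from compound 1 to compound 4 (within the scatter) and this is the first comparison here in which only one place differs, so the size of a step can be read directly rather than guessed from a spread of values. At this place, on an aromatic carbon of a six-membered ring, losing the whole dimethylamino group and putting a hydrogen in its place produces no difference that this read-out can separate from the scatter, though that is a single pair and sets no general rule. Nothing measured here explains why the number holds still when these atoms leave.

On these data alone, whether other groups at the same place, such as a carboxylic acid, a primary amine or a longer alkyl chain, would also leave the number within the scatter remains open. Also open, as far as these compounds go, is whether hydrogen in place of dimethylamino would give a similar step on a different core, since this one pair speaks only for the core of compound 1.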